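Swapping the aromatic group of compound 2

The source may hold more compounds than are shown below. What is called first, only, known or untested is meant among the compounds shown, and "the series" means these compounds.

Values in a functional assay on MDA-MB-231 cells (Homo sapiens) for inhibition, read by MTT assay, with a stated time of 72 h; on this read-out lower numbers stand for stronger inhibition and higher numbers for weaker inhibition:
- Compound 1 `Cc1ccc(-c2cc(C(=O)N3CCC4(CC3)CC(=O)c3nn(C(C)(C)C)cc3O4)c3ccccc3n2)cc1`: > 10000 nM (a limit)
- Compound 2 `COc1ccc(-c2cc(C(=O)N3CCC4(CC3)CC(=O)c3nn(C(C)(C)C)cc3O4)c3ccccc3n2)cc1OC`: 7130 nM

Compound 1 gives > 10000 nM, which is a limit of the assay and not a number. Among the measured compounds shown here, compound 2 gives 7130 nM, the only true number so far, so it has no measured neighbour to be ranked against.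

Compound 3 `CN(C)c1ccc(-c2cc(C(=O)N3CCC4(CC3)CC(=O)c3nn(C(C)(C)C)cc3O4)c3ccccc3n2)cc1` carries 4-(dimethylamino)phenyl in place of 3,4-dimethoxyphenyl on an aromatic carbon, and the rest of the molecule stays the same: 4-(dimethylamino)phenyl in place of 3,4-dimethoxyphenyl on an aromatic carbon.

For the measured compounds named here, only one measured step bears on this change, as it swaps a group on that same aromatic carbon: an at least 1.4-fold lower number from compound 1 to compound 2 (0.14 log units; that floor lies within the scatter). As far as these compounds go, its floor lies within the scatter, and the true size stays open. That gives no firm sign that this position moves the value much, so no clear direction can be expected in this assay.

The expected change is a 1.1-fold higher number from compound 2 to compound 3 (0.02 log units; within the scatter), which is no step beyond the scatter. Compound 3 is estimated at 7500 nM, with an expected range from 3000 nM to 15000 nM.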

Compound 3, half-maximal inhibitory concentration: > 10000 nM
Compound 3: no number, only a limit (the forecaster's own chance of this, stated with the estimate: 40%); middle value at least 1.3-fold (0.12 log units) from the limit.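

In this assay compound 3 gives > 10000 nM, which is a limit of the assay and not a number. Among the compounds shown here, putting 4-(dimethylamino)phenyl in place of 3,4-dimethoxyphenyl gives an at least 1.4-fold higher number from compound 2 to compound 3 (0.14 log units; that floor lies within the scatter), so this change cannot be called a real loss, yet 3,4-dimethoxyphenyl is now the only one of the three groups on this aromatic carbon that comes with a true number. The step between compound 1 and compound 3 cannot be read, since both values stop at the same limit, and the assay therefore cannot separate these two groups: the limit of > 10000 nM in this assay, at which 2 of the 3 values shown sit.

As far as these compounds go, the true size of both readable steps stays open, and so does whether any group on this aromatic carbon can give a number clearly lower than that of compound 2, at 7130 nM. A phenyl ring carrying a hydroxyl group or a fluorine atom, or a pyridine ring in place of the phenyl, would test whether this position can move the value at all.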